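Trifluoromethyl pyrazole series: aryl amine replacing piperidine

The source may hold more compounds than are shown below. What is called first, only, known or untested is meant among the compounds shown, and "the series" means these compounds.

Compound 3 `FC(F)(F)c1cc(NC[C@H]2CCCCN2)c2cn[nH]c2c1` gives 69% in an assay for inhibition of Indoleamine 2,3-dioxygenase 1 (Homo sapiens), with stated times of 10 min and 60 min, tested at 100 uM (on this read-out higher numbers stand for a stronger effect at the one concentration tested and lower numbers for a weaker effect), level with compound 1 `O=[N+]([O-])c1cccc(CNc2cc(C(F)(F)F)cc3[nH]ncc23)c1` at 69%, the two together the highest of the three numbers; compound 2 `OC1CCCC(Nc2cccc(CNc3cc(C(F)(F)F)cc4[nH]ncc34)c2)C1` lies furthest away at 2%. Compound 4 `Nc1cccc(CNc2cc(C(F)(F)F)cc3[nH]ncc23)c1` is not yet measured. It differs from compound 3 by 3-aminophenyl in place of piperidin-2-yl on a saturated chain carbon bound to a nitrogen on an aromatic ring. Among the measured compounds shown here, no measured step mirrors this swap of a saturated ring for an aromatic one. For the measured compounds named here, the only recorded step, a number 67 percentage points lower from compound 1 to compound 2 (beyond the scatter), shows that a change on the aromatic ring of the benzylamine side can move the read-out a long way, so the substituent pattern on that ring matters. Compound 4 carries the 3-aminophenyl group, with one hydrogen-bond donor and one acceptor as counted, and its step from compound 3 is expected to be a number 24 percentage points lower from compound 3 to compound 4 (beyond the scatter), a drop of moderate size with wide uncertainty. Compound 4 is estimated at 45%, within 10% to 75%.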

Compound 4, a percentage reported as inhibition, at one concentration (the size of the read-out at that concentration, not a potency): 55%
Beside the measured number, compound 4's estimate is 10 percentage points below it; low and high end bracket the measured number.
By their numbers in this assay, from the lowest: compound 2; then compound 4; then compounds 1 and 3 (each within the scatter of the next).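

In this assay, piperidin-2-yl is not essential on the saturated chain carbon bound to a nitrogen on an aromatic ring: 3-aminophenyl retains a clear read-out, although at a modest cost (a number 14 percentage points lower from compound 3 to compound 4 (beyond the scatter)). On the aromatic carbon, amino in place of nitro also carries only a modest cost (a number 14 percentage points lower from compound 1 to compound 4 (beyond the scatter)). The large loss seen with the (3-hydroxycyclohexyl)amino group is mostly recovered when hydrogen replaces 3-hydroxycyclohexyl on the nitrogen (a number 53 percentage points higher from compound 2 to compound 4 (beyond the scatter)), which ties that loss to the 3-hydroxycyclohexyl group rather than to the nitrogen.

Still open, going by these compounds, is whether a methyl or acetyl group on that nitrogen, or a carboxylic acid on that aromatic carbon, would hold the read-out. Nothing available explains these steps.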